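The source may report more compounds than this note shows. Statements on the series, on what has been measured and on what is new or still open speak of the compounds shown alone.

Measured so far:
- compound 1 `O=C(NCc1ccc(S(=O)(=O)c2ccccc2)cc1)NCc1cccnc1`: 610 nM
- compound 2 `CC(C)n1cc(S(=O)(=O)c2ccc(CNC(=O)N3Cc4ccncc4C3)cc2)cn1`: 11 nM

In a functional assay on A2780 cells (Homo sapiens) for cytotoxicity, read by sulforhodamine B assay, with a stated time of 72 h (on this read-out lower numbers stand for stronger inhibition and higher numbers for weaker inhibition), compound 2 gives 11 nM, the lower of the two numbers and therefore the stronger inhibition. Compound 1 gives 610 nM, and this gap lies well beyond the usual scatter. The two compounds differ in more than one place, so the gap cannot be tied to any single group.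

The next compound, compound 3 `CC(=O)N1CCC(S(=O)(=O)c2ccc(CNC(=O)N3Cc4ccncc4C3)cc2)CC1`, has 1-acetylpiperidin-4-yl in place of 1-isopropyl-1H-pyrazol-4-yl on a sulfonyl sulfur. Everything else matches compound 2. Going by the values given here, no measured pair shows what this exchange does, so the expectation is uncertain. Among the compounds with values here, the natural starting point is compound 2 at 11 nM, since only this one group changes.

The expected result is a small move towards a higher number, not clearly beyond the scatter, and the estimated step is a 1.8-fold higher number from compound 2 to compound 3 (0.26 log units; within the scatter). For compound 3 the estimated value is 20 nM, with an expected range from 5 nM to 80 nM.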

Compound 3, half-maximal inhibitory concentration: 110 nM
Compound 3: the middle estimate sits 5.5-fold (0.74 log units) below what was measured; measured number above the stated range.
By their numbers in this assay, from the lowest: compound 2; then compound 3; then compound 1.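

In this assay, the group on the sulfonyl sulfur clearly matters: putting 1-acetylpiperidin-4-yl in place of 1-isopropyl-1H-pyrazol-4-yl gives a 10-fold higher number from compound 2 to compound 3 (1.00 log units; beyond the scatter), so this one position alone can shift the number beyond the usual scatter. The earlier comparison could not show this, since compound 1 and compound 2 differ in more than one place. The exchange replaces a five-membered aromatic ring with a six-membered non-aromatic ring and adds a double bond outside aromatic rings, but no supporting measurement shows which of these differences matters or explains the higher number.

This single exchange leaves open whether the ring or the group attached to it accounts for the step, since both change together. A 1-methyl-1H-pyrazol-4-yl group, with methyl in place of isopropyl, or a piperidin-4-yl group with a free amine in place of the acetyl-bearing nitrogen, would change only one of these parts and could begin to separate them.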